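The source may report more compounds than this note shows. Statements on the series, on what has been measured and on what is new or still open speak of the compounds shown alone.

Measured compounds in a functional assay on PC-3 cells (Homo sapiens) for inhibition, read by MTT assay, with a stated time of 96 h; a lower number here means a stronger inhibitor of growth, a higher number a weaker inhibitor of growth:

compound 1, `O=C(NCCCCCCSSCCCCCCNC(=O)c1cc(-c2ccncc2)n[nH]1)c1cc(-c2ccncc2)n[nH]1`, 4740 nM
compound 2, `O=C(OCc1ccccc1)SCCCCCCNC(=O)c1cc(-c2ccncc2)n[nH]1`, 15400 nM
compound 3, `CCCC(=O)SCCCCCCNC(=O)c1cc(-c2ccncc2)n[nH]1`, 32100 nM

Compound 2 stands second highest of the three numbers in this assay. Its nearest neighbour is compound 3; the furthest is compound 1, whose number is the lowest of the set.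

The step to be considered leads from compound 2 to compound 4, `CSCCCCCCNC(=O)c1cc(-c2ccncc2)n[nH]1`, a compound not yet measured in this assay. The change is methyl in place of benzyloxycarbonyl on a sulfur.

Within the data shown here, only one measured step touches the group on this sulfur: a 2.1-fold higher number from compound 2 to compound 3 (0.32 log units; beyond the scatter). That step replaces benzyloxy on the carbonyl carbon with propyl, so the carbonyl itself stays in place; the change to compound 4 removes the whole benzyloxycarbonyl and leaves a methyl on the sulfur. Among the measured compounds shown here, no measured pair shows a sulfur bearing a simple alkyl group, so the step from compound 2 to compound 3 is the only guide and it was modest. The direction it suggests is toward a higher number when the group on the sulfur shrinks.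

Compound 4 is therefore expected to give a higher number than compound 2 in this assay, with a step of about a 2.6-fold higher number from compound 2 to compound 4 (0.41 log units; beyond the scatter). The estimate for compound 4 is 40000 nM, in the range 15000 nM to 100000 nM.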

Compound 4, concentration for 50% growth inhibition: > 50000 nM
Compound 4: no number, only a limit (the forecaster's own chance of this, stated with the estimate: 25%); middle value at least 1.2-fold (0.09 log units) from the limit.
By their numbers in this assay, from the lowest: compound 1; then compound 2; then compound 3. At a limit, above all of these: compound 4.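

In this assay compound 4 gives > 50000 nM as a limit of the assay and not a number, so this sulfur position now has a member with no measurable growth inhibition up to that limit. Removing the whole benzyloxycarbonyl and leaving methyl gives an at least 3.2-fold higher number from compound 2 to compound 4 (0.51 log units; beyond the scatter) as a lower bound, and the true step may be larger; the earlier change, which kept the carbonyl, gave a 2.1-fold higher number from compound 2 to compound 3 (0.32 log units; beyond the scatter) and could not show how the series reads without a carbonyl on the sulfur. Methyl in place of propylcarbonyl gives an at least 1.5-fold higher number from compound 3 to compound 4 (0.19 log units; that floor lies within the scatter) and so does not separate compound 4 from compound 3 with any confidence, which means that loss of the carbonyl alone cannot be singled out as the source of the step from compound 2.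

Going by these compounds, how far the value of compound 4 lies past its limit stays open, and with it the full size of both new steps. Also open, on these data alone, is how a free thiol, a longer alkyl chain or an amine on this sulfur would read against the methyl and the two carbonyl-bearing groups.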